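This account rests on a few compounds, and the source may have more. Where it says the series, first, only, none or still open, it means among the compounds named here.

The measured compounds and their values:

Compound 1, `CNc1ccnc2c1ncn2[C@@H]1O[C@H](CO)[C@](O)(CO)[C@H]1O`, in an ADME assay on Huh-7 cells (Homo sapiens) for cytotoxicity, read by WST assay, with a stated time of 3 days (on this read-out higher numbers stand for lower toxicity in this test and lower numbers for higher toxicity in this test), gives 11800 nM.
Compound 2, `CNc1ccnc2c1ncn2[C@@H]1O[C@H](CO)[C@](O)(CF)[C@H]1O`, in this assay gives > 100000 nM, which is a limit of the assay and not a number.
Compound 3, `[N-]=[N+]=NC[C@@]1(O)[C@@H](CO)O[C@@H](n2cnc3c(N)ccnc32)[C@@H]1O`, in this assay gives > 100000 nM, which again is a limit of the assay rather than a number.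

Compound 3 therefore stands at the limit of > 100000 nM in this assay, at which 2 of the 3 values shown sit. Only compound 1 gives a number here, so compound 3 cannot be placed against it beyond saying that compound 3 sits at the limit while compound 1 does not.

Compound 4, `CNc1ccnc2c1ncn2[C@@H]1O[C@H](CO)[C@](O)(CN=[N+]=[N-])[C@H]1O`, differs from compound 3 by methyl in place of hydrogen on a nitrogen on an aromatic ring. Among the compounds with values here, the single measured step, an at least 8.4-fold higher number from compound 1 to compound 2 (0.92 log units; beyond the scatter), concerns a change on a saturated chain carbon and not on the ring nitrogen, so no measured step bears directly on the change from compound 3 to compound 4. What can be said is that compound 1 and compound 2 both carry the methylamino group, and one of them gives a number while the other sits at the limit.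

Within the data shown here, with compound 3 at the limit and no comparable step in hand, no step beyond the scatter is expected, and compound 4 is estimated at 100000 nM (range 30000 nM to 300000 nM), the expected step being a number no higher from compound 3 to compound 4 (the limit leaves the size open).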

Compound 4, half-maximal cytotoxic concentration: > 100000 nM
Compound 4 gave a limit, no number (the forecaster's own chance of this, stated with the estimate: 60%); the middle value sits exactly at the limit.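

In this assay compound 4 gives > 100000 nM, which is a limit of the assay and not a number. With the methylamino group kept, azido in place of hydroxy on the saturated chain carbon bound to a saturated ring carbon gives an at least 8.4-fold higher number from compound 1 to compound 4 (0.92 log units; beyond the scatter), so a second replacement of the hydroxy at this place now shows a step beyond the scatter, alongside an at least 8.4-fold higher number from compound 1 to compound 2 (0.92 log units; beyond the scatter). The steps from compound 3 to compound 4 and from compound 2 to compound 4 cannot be read, so neither methyl in place of hydrogen on the aromatic ring nitrogen nor azido in place of fluoro can be given a size, and the values now gather at a single mark: the limit of > 100000 nM in this assay, at which 3 of the 4 values shown sit.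

As far as these compounds go, only compound 1 gives a number, so what methyl in place of hydrogen on that nitrogen does while the hydroxy stays on the chain carbon remains open. Also open, from the compounds shown here alone, is whether an amine or a methoxy group on the chain carbon would stay at this limit or give a number, and how an ethyl group in place of the methyl would read.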